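Chloro to Formyl on the Pyridine Ring of Compound 3

The compounds below may be only part of what the source reports. "The series", "measured", "known", "first", "only" and "open" are said of these compounds alone.

Compound 1, `O=C(Nc1ccc(Oc2ccccc2)cc1)N1CCN(c2ncccc2C(F)(F)F)CC1`: 916 nM
Compound 2, `CC(C)(C)c1ccc(NC(=S)N2CCN(c3ncccc3C(F)(F)F)CC2)cc1`: 441 nM
Compound 3, `CC(C)c1ccc(NC(=O)N2CCN(c3ncccc3Cl)CC2)cc1`: 17.3 nM

In a functional assay on HEK293 cells for antagonist activity at transient receptor potential cation channel subfamily V member 1 (Rattus norvegicus) (on this read-out lower numbers stand for stronger inhibition and higher numbers for weaker inhibition), compound 3 holds the lowest number of the three. Compound 2 stands well above it and compound 1 higher still; both separations lie beyond the scatter of the assay, so compound 3 is the most potent of the measured set. Compound 4, `CC(C)c1ccc(NC(=O)N2CCN(c3ncccc3C=O)CC2)cc1`, differs from compound 3 in a single place: formyl in place of chloro on an aromatic carbon. Among the measured compounds shown here, no measured pair shows this particular exchange, so the size of the step rests on judgment rather than on a known precedent. The other two compounds change several groups at once and cannot be read as a guide for this one exchange. A moderate loss is expected from compound 3 to compound 4, one that should exceed the scatter while leaving compound 4 closer to compound 3 than to compound 2. Compound 4 is therefore estimated at 60 nM, with a likely range from 15 nM to 300 nM. The step of a 3.5-fold higher number from compound 3 to compound 4 (0.54 log units; beyond the scatter) is expected to run toward weaker inhibition.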

Compound 4, half-maximal inhibitory concentration: 1400 nM
The estimate for compound 4 lay 23-fold (1.37 log units) below the measured number; the measured number lies above the stated range.
By their numbers in this assay, from the lowest: compound 3; then compound 2; then compounds 1 and 4 (each within the scatter of the next).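

In this assay, 3-formylpyridin-2-yl in place of 3-chloropyridin-2-yl brings an 81-fold higher number from compound 3 to compound 4 (1.91 log units; beyond the scatter), a large step well beyond the scatter. Among the compounds shown here, this is the first pair in the set that isolates a change at this position, ortho to a large group and two atoms from the ring nitrogen, and it shows that this one exchange, with the rest of the structure held constant, is enough to weaken inhibition sharply. Nothing available explains the loss.

The compounds shown leave open how a methyl, a nitrile or a hydroxymethyl group would fare at this position. As far as these compounds go, compound 1 and compound 2 carry trifluoromethyl here but also differ elsewhere, so the effect of that group at this position also remains open.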